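A few compounds are considered here, and "the series" means these few. Any claim that something is new, unique, unknown or untested is made for them only; others in the source may bear on it.

Working notes on the shared core of compound 1 `Cc1cc(NCc2cccnc2)n2nc(C)c(-c3ccccc3)c2n1` in a physicochemical assay for solubility, read by HPLC, using the shake flask method, measured as kinetic solubility, with a stated time of 2 h, at pH 7.4; a lower number here means a less soluble compound, a higher number a more soluble compound. Compound 1 gives 110000 nM. Compound 2 `Cc1cc(NCc2nccn2C)n2nc(C)c(-c3ccccc3)c2n1` gives 26900 nM, and compound 3 `Cc1cc(NCc2c[nH]cn2)n2nc(C)c(-c3ccccc3)c2n1` gives 14600 nM. The steps run a 4.1-fold lower number from compound 1 to compound 2 (0.61 log units; beyond the scatter) and a 7.5-fold lower number from compound 1 to compound 3 (0.88 log units; beyond the scatter), while a 1.8-fold lower number from compound 2 to compound 3 (0.27 log units; within the scatter), so compound 3 holds the lowest of the three numbers, though its gap to compound 2 is not one to build on.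

Compound 4 `Cc1cc(NCc2nccs2)n2nc(C)c(-c3ccccc3)c2n1` is the next member. It differs from compound 3 by 1,3-thiazol-2-yl in place of 1H-imidazol-4-yl on a saturated chain carbon bound to a nitrogen on an aromatic ring. Among the measured compounds shown here, none of the measured steps swaps one five-membered ring for another five-membered ring of this kind; the only step between two five-membered rings is a 1.8-fold lower number from compound 2 to compound 3 (0.27 log units; within the scatter), and the larger steps both start from compound 1 with its six-membered ring. The evidence for the change in hand is therefore thin, and the closest comparison points to a small step.

On that basis the expected step is a 1.0-fold higher number from compound 3 to compound 4 (0.01 log units; within the scatter), and compound 4 is estimated at 15000 nM, with a range from 4000 nM to 60000 nM.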

Compound 4, solubility: 108000 nM
Beside the measured number, compound 4's estimate is 7.2-fold (0.86 log units) below it; measured number above the stated range.
By their numbers in this assay, from the lowest: compounds 3 and 2 (each within the scatter of the next); then compounds 4 and 1 (each within the scatter of the next).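

At this position, on a saturated chain carbon bound to a nitrogen on an aromatic ring, exchanging one five-membered aromatic ring for another can produce a step beyond the scatter in this assay: 1,3-thiazol-2-yl gives a 7.4-fold higher number from compound 3 to compound 4 (0.87 log units; beyond the scatter) and a 4.0-fold higher number from compound 2 to compound 4 (0.60 log units; beyond the scatter). Ring size does not sort the series, since the step from pyridin-3-yl to 1,3-thiazol-2-yl, a 1.0-fold lower number from compound 1 to compound 4 (0.01 log units; within the scatter), lies within the scatter, whereas the imidazole-bearing compound 2 and compound 3 both stand apart from that pair. Nothing available explains these steps.

As far as these compounds go, whether a 1,3-oxazol-2-yl or a plain phenyl group at this position would fall with compound 1 and compound 4 or with compound 2 and compound 3 remains open. Also open, from the compounds shown here alone, is whether the 1,3-thiazol-2-yl result carries over to a longer chain.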